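A few compounds are considered here, and "the series" means these few. Any claim that something is new, unique, unknown or untested is made for them only; others in the source may bear on it.

Measured in an ADME assay on MDCK cells (Canis lupus familiaris) for cytotoxicity, read by MTT assay, with a stated time of 48 h; a lower number here means that less compound is tolerated, a higher number that more compound is tolerated:
- compound 1 `COc1cccc([C@H]2CC(C)(F)[C@@H]3CC[C@@H](C)C[C@H]3O2)c1OC`: 180000 nM
- compound 2 `COc1ccc([C@H]2CC(C)(F)[C@@H]3CC[C@@H](C)C[C@H]3O2)c(OC)c1`: 379000 nM

Compound 2 stands highest of the two numbers in this assay; its nearest neighbour is compound 1, whose number is lower by a gap that lies beyond the scatter. Compound 3 `COc1ccc([C@H]2CC(C)(F)[C@@H]3CC[C@@H](C)C[C@H]3O2)c(OC)c1OC` differs from compound 2 by methoxy in place of hydrogen on an aromatic carbon, a methoxy in place of hydrogen on an aromatic carbon. Within the data shown here, no matched step of this kind is among the measured pairs, so the expectation is a step in this assay of no more than the scatter, in either direction. Compound 3 is therefore expected at 300000 nM, between 120000 nM and 700000 nM, which means an expected step of a 1.3-fold lower number from compound 2 to compound 3 (0.10 log units; within the scatter).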

Compound 3, half-maximal cytotoxic concentration: 133000 nM
Estimate against measurement, compound 3: 2.3-fold (0.35 log units) above, and the stated range covers the measured number.
By their numbers in this assay, from the lowest: compounds 3 and 1 (each within the scatter of the next); then compound 2.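

In this assay, methoxy in place of hydrogen on the aromatic carbon ortho to two methoxy groups gives a 2.8-fold lower number from compound 2 to compound 3 (0.45 log units; beyond the scatter) and so shows that this carbon is not indifferent to the change. Methoxy in place of hydrogen on a different carbon of the ring gives a 1.4-fold lower number from compound 1 to compound 3 (0.13 log units; within the scatter) and leaves the number within the scatter, so the same change does not give a step of the same size at both places. Nothing measured here explains that difference. As far as these compounds go, it remains open whether an amine or a hydroxyl group on the carbon ortho to two methoxy groups would give a step like that of methoxy.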